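The source may hold more compounds than are shown below. What is called first, only, known or untested is meant among the compounds shown, and "the series" means these compounds.

Measured compounds:
- compound 1, `CN(C(=O)c1ccccc1OCc1ccccc1)[C@@H]1CCC[C@H](N)C1`: 3150 nM
- compound 2, `CC(C)N(C(=O)c1ccccc1OCc1ccccc1)[C@@H]1CCC[C@H](N)C1`: 8780 nM

Among the measured compounds shown here, in an assay on HEK293 cells for inhibition of transient receptor potential cation channel subfamily M member 8 (Homo sapiens), read by FLIPR and calcium flux (on this read-out higher numbers stand for weaker inhibition and lower numbers for stronger inhibition), compound 2 stands highest of the two numbers so far; its nearest neighbour is compound 1, and the step of a 2.8-fold higher number from compound 1 to compound 2 (0.45 log units; beyond the scatter) lies beyond the scatter, so the two are distinct on this read-out. The new compound 3, `N[C@H]1CCC[C@@H](N(CC2CC2)C(=O)c2ccccc2OCc2ccccc2)C1`, continues the substituent series on the amide-type nitrogen: cyclopropylmethyl in place of isopropyl on an amide-type nitrogen. For the measured compounds named here, only one measured step bears on this position, the exchange from compound 1 to compound 2, which gave a 2.8-fold higher number from compound 1 to compound 2 (0.45 log units; beyond the scatter) with a modest rise in the number when a larger group replaced the smaller. Going by the values given here, the change to compound 3 again enlarges the group on the same nitrogen, so the expectation for this assay is a number at or somewhat above that of compound 2, with the direction of the earlier step kept but its size uncertain, because the step of a 2.8-fold higher number from compound 1 to compound 2 (0.45 log units; beyond the scatter) is the only guide. For compound 3 the estimated step is a 1.3-fold higher number from compound 2 to compound 3 (0.10 log units; within the scatter). Compound 3 is therefore expected to give about 11000 nM in this assay, with a range from 4500 nM to 27000 nM.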

Compound 3, half-maximal inhibitory concentration: 593 nM
The estimate for compound 3 lay 19-fold (1.27 log units) above the measured number, and the stated range ends above it.
By their numbers in this assay, from the lowest: compound 3; then compound 1; then compound 2.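

In this assay, enlarging the group on the amide-type nitrogen does not move the number in one direction: a 15-fold lower number from compound 2 to compound 3 (1.17 log units; beyond the scatter) runs opposite to a 2.8-fold higher number from compound 1 to compound 2 (0.45 log units; beyond the scatter) and is the larger of the two, so compound 2 stands against any reading in which a larger group simply gives weaker inhibition. Cyclopropylmethyl also improves on methyl, with a 5.3-fold lower number from compound 1 to compound 3 (0.73 log units; beyond the scatter), which makes compound 3 the strongest inhibitor of the three, and both of its steps lie beyond the scatter. Nothing available explains why isopropyl and cyclopropylmethyl differ so sharply at this position.

The compounds shown leave open whether the lower number of compound 3 goes with the three-membered ring itself or with the saturated chain carbon that carries it; an isobutyl, n-butyl or cyclobutylmethyl group on the same nitrogen would separate these readings. Also open, going by these compounds, is whether the cyclopropylmethyl advantage holds when the benzyloxy group or the free amine of the shared core is changed.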